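The source may report more compounds than this note shows. Statements on the series, on what has been measured and on what is new or still open speak of the compounds shown alone.

Working notes on the series.

Compound 1 `CN(c1ccc(NC(=O)c2ccc(Br)cc2)cc1OCc1cc(Cl)ccc1Cl)S(C)(=O)=O` is the starting point. In a functional assay on SK-BR-3 cells (Homo sapiens) for antiproliferative activity, read by MTT assay, with a stated time of 48 h (on this read-out higher numbers stand for weaker inhibition and lower numbers for stronger inhibition), compound 1 gives 2290 nM. Compound 2 `COc1ccc(C(=O)Nc2ccc(N(C)S(C)(=O)=O)c(OCc3cc(Cl)ccc3Cl)c2)cc1` differs from compound 1 by one change only, (methoxy in place of bromo on an aromatic carbon). In this assay compound 2 gives 490 nM. The step is a 4.7-fold lower number from compound 1 to compound 2 (0.67 log units; beyond the scatter).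

Compound 3 `COc1ccc(OC)c(COc2cc(NC(=O)c3ccc(Br)cc3)ccc2NS(C)(=O)=O)c1` carries a different core, and the difference between the core of compound 3 and the core of compound 1 is not broken down here. In this assay compound 3 gives 9.58 nM, the lowest number among the three measured compounds, with both other steps beyond the scatter.

Compound 4 `COc1ccc(C(=O)Nc2ccc(NS(C)(=O)=O)c(OCc3cc(OC)ccc3OC)c2)cc1` is not yet measured. It differs from compound 3 by methoxy in place of bromo on an aromatic carbon. This is the same change as from compound 1 to compound 2, made at the same kind of place, and it occurs twice in all among the compounds shown.

Among the measured compounds shown here, the expectation for compound 4 rests on the only precedent for this change, a 4.7-fold lower number from compound 1 to compound 2 (0.67 log units; beyond the scatter), which was made on the core of compound 1. On the core of compound 3 the same change is expected to give a step of a 2.7-fold lower number from compound 3 to compound 4 (0.44 log units; beyond the scatter), taken somewhat smaller than the precedent since compound 3 already stands at 9.58 nM. Compound 4 is therefore estimated at 3.5 nM in this assay, with a plausible range from 1.2 nM to 12 nM.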

Compound 4, half-maximal inhibitory concentration: 13.4 nM
The estimate for compound 4 lay 3.8-fold (0.58 log units) below the measured number; the whole stated range lies below it.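

On the core of compound 3, methoxy in place of bromo gives a 1.4-fold higher number from compound 3 to compound 4 (0.15 log units; within the scatter), so in this assay this pair shows no change that can be told from the scatter. The lower number seen with this change on the core of compound 1 therefore does not carry over to the core of compound 3, and the size of the step depends on the core in this series: the same change on two cores in this assay, a 4.7-fold lower number (0.67 log units; beyond the scatter) from compound 1 to compound 2 and a 1.4-fold higher number (0.15 log units; within the scatter) from compound 3 to compound 4, 6.5-fold (0.82 log units) apart, beyond the scatter of two such steps

This rests on one pair per core, so it shows that the step cannot be assumed to transfer, but it does not show which part of the core difference sets the gap or how the change would read on a third core.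

The compounds shown leave open which feature of the core of compound 3 accounts for its low number, since no compound separates the parts of the core difference from one another. They also leave open how other groups would read on the aromatic carbon that holds bromo or methoxy, for example an amine, a carboxylic acid or a longer chain such as butoxy, on either core.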